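Trimming the hydroxyalkyl tail of compound 3

The source may report more compounds than this note shows. Statements on the series, on what has been measured and on what is new or still open speak of the compounds shown alone.

Compound 3 `COc1cc(NC(C)CCCNC(=O)NNC(=O)NCCCCCO)c2ncccc2c1` stands together with compound 1 at the lowest of three numbers in a functional assay on MCF7 cells (Homo sapiens) for inhibition, read by MTT assay, with a stated time of 4 days (on this read-out lower numbers stand for stronger inhibition and higher numbers for weaker inhibition), where compound 3 gives 4000 nM. Compound 1 `COc1cc(NC(C)CCCNC(=O)Nc2ccc(Cl)c(C(F)(F)F)c2)c2ncccc2c1` gives 4000 nM, and the step of no change at the digits printed from compound 1 to compound 3 (within the scatter) shows the two are level. Among the measured compounds shown here, compound 2 `COc1cc(NC(C)CCCNC(=O)NN)c2ncccc2c1` gives 16000 nM, and the step of a 4.0-fold lower number from compound 2 to compound 3 (0.60 log units; beyond the scatter) is the only step beyond the scatter, gained by adding the (5-hydroxypentyl)carbamoyl group.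

Compound 4 `COc1cc(NC(C)CCCNC(=O)NNC(=O)NCCO)c2ncccc2c1` keeps that carbamoyl group but shortens its chain: hydroxy in place of 3-hydroxypropyl on a saturated chain carbon, two bonds along the chain from an amide-type nitrogen. For the measured compounds named here, no measured step tests the length of this chain; the steps at hand only show that the whole (5-hydroxypentyl)carbamoyl group adds something over hydrogen and matches the aryl group of compound 1. With no comparison of chain lengths to lean on, compound 4 is expected to show a step of a 1.1-fold higher number from compound 3 to compound 4 (0.05 log units; within the scatter), within the scatter. Compound 4 is therefore estimated at 4500 nM, with a range from 1800 nM to 12000 nM.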

Compound 4, half-maximal inhibitory concentration: 13000 nM
The estimate for compound 4 lay 2.9-fold (0.46 log units) below the measured number; the whole stated range lies below it.
By their numbers in this assay, from the lowest: compounds 1 and 3 (each within the scatter of the next); then compounds 4 and 2 (each within the scatter of the next).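

In this assay, the length of the chain on this carbamoyl group proves to matter: replacing 5-hydroxypentyl with 2-hydroxyethyl gives a 3.3-fold higher number from compound 3 to compound 4 (0.51 log units; beyond the scatter) and so gives up the level reached with the aryl group of compound 1, as a 3.3-fold higher number from compound 1 to compound 4 (0.51 log units; beyond the scatter) shows. Among the compounds shown here, the carbamoyl group with its terminal hydroxy is therefore not enough on its own, for with the shorter chain the step of a 1.2-fold lower number from compound 2 to compound 4 (0.09 log units; within the scatter) stays within the scatter, and the gain over the free amino group is seen only with the 5-hydroxypentyl chain. Nothing measured here accounts for this loss.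

With only two chain lengths compared, the compounds shown leave open how the number moves with a 3-hydroxypropyl chain, a 4-hydroxybutyl chain or a longer chain. They also leave open whether the terminal hydroxy itself counts, which a plain pentyl chain or a pentyl chain ending in an amine or a carboxylic acid would test.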